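This account rests on a few compounds, and the source may have more. Where it says the series, first, only, none or still open, it means among the compounds named here.

Measured compounds in a functional assay on MDA-MB-231 cells (Homo sapiens) for antiproliferative activity, read by MTT assay, with a stated time of 72 h; a higher number here means a weaker inhibitor, a lower number a stronger inhibitor:
- compound 1, `CN(C)CCn1cnnc1-c1cc(Oc2ccc(NC(=O)Nc3ccc(Cl)c(C(F)(F)F)c3)cc2F)ccn1`, gives 1070 nM
- compound 2, `CCN(CC)CCn1cnnc1-c1cc(Oc2ccc(NC(=O)Nc3ccc(Cl)c(C(F)(F)F)c3)cc2F)ccn1`, gives 1540 nM
- compound 3, `CN(C)CCCn1cnnc1-c1cc(Oc2ccc(NC(=O)Nc3ccc(Cl)c(C(F)(F)F)c3)cc2F)ccn1`, gives 7880 nM

Compound 3 stands at the highest of the three numbers in this assay: compound 1 lies a 7.4-fold higher number from compound 1 to compound 3 (0.87 log units; beyond the scatter) away and compound 2 a 5.1-fold higher number from compound 2 to compound 3 (0.71 log units; beyond the scatter) away, both beyond the scatter, whereas compound 1 and compound 2 differ only by a 1.4-fold higher number from compound 1 to compound 2 (0.16 log units; within the scatter), within the scatter.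

Compound 4, `O=C(Nc1ccc(Oc2ccnc(-c3nncn3C3CC3)c2)c(F)c1)Nc1ccc(Cl)c(C(F)(F)F)c1`, is the next member: cyclopropyl in place of 3-(dimethylamino)propyl on an aromatic nitrogen.

Going by the values given here, no measured step removes the amine or introduces a ring on this aromatic nitrogen, so the change is not directly covered. The steps that come closest are those altering the chain on the same nitrogen: going from compound 1 to compound 3 and from compound 2 to compound 3 each lengthened the chain and each raised the number by a modest amount, while the swap from compound 1 to compound 2 left it unchanged. On these data alone, compound 4 carries a shorter group than any of the three, which argues against a number higher than compound 3, but the loss of the amine is untested. Compound 4 is therefore expected to return to roughly the range of compound 1 and compound 2, a step of a 3.9-fold lower number from compound 3 to compound 4 (0.60 log units; beyond the scatter) from compound 3, with a wide range. The estimate for compound 4 in this assay is 2000 nM, between 500 nM and 10000 nM.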

Compound 4, half-maximal inhibitory concentration: > 50000 nM
Compound 4: only a limit was reported; the forecaster's own chance of this, stated with the estimate: 5%; middle value at least 25-fold (1.39 log units) from the limit.
By their numbers in this assay, from the lowest: compounds 1 and 2 (each within the scatter of the next); then compound 3. At a limit, above all of these: compound 4.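

Compound 4 gives > 50000 nM in this assay and that value is a limit, not a number. With cyclopropyl on the aromatic nitrogen, the series reads as an at least 46-fold higher number from compound 1 to compound 4 (1.66 log units; beyond the scatter) and as an at least 32-fold higher number from compound 2 to compound 4 (1.51 log units; beyond the scatter) and as an at least 6.3-fold higher number from compound 3 to compound 4 (0.80 log units; beyond the scatter) and all three steps lie beyond the scatter. The earlier compounds varied only the chain and the alkyl groups on its amine, whereas this change shows that the substituent on this nitrogen can do far more than those changes did: the shortest group shown, carrying no amine, stands above compound 1, compound 2 and compound 3 rather than returning to the level of the shorter chains, so chain length alone does not order the series.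

The change removes the amine and brings in a ring at once, so the compounds shown cannot tell which of the two accounts for the step. A plain propyl chain, a 2-morpholinoethyl chain or a cyclopropyl ring bearing a dimethylamino group would help to separate these two parts of the change.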